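A Methoxy Swap on the Benzylidene Ring of Compound 3

The source may report more compounds than this note shows. Statements on the series, on what has been measured and on what is new or still open speak of the compounds shown alone.

Compound 3 `Cc1ccc(/C=C2/N=C(c3ccccc3)N(C(=O)c3ccc(C)cc3)NC2=O)cc1` was tested in a functional assay on the whole organism (strain albino) with Mus musculus as the target, with a stated time of 0.5 h (on this read-out higher numbers stand for an effect only at larger amounts of compound and lower numbers for an effect already at smaller amounts), where compound 3 gives 100 mg/kg. Compound 1 `COc1ccc(/C=C2/N=C(c3ccccc3)N(C(=O)c3ccc(Cl)cc3)NC2=O)cc1` gives 100 mg/kg, so compound 3 stands level with compound 1 at the digits shown, and together they carry the highest numbers of the three measured compounds. Compound 2 `Cc1ccc(C(=O)N2NC(=O)/C(=C\c3ccc(O)cc3)N=C2c2ccccc2)cc1` gives 30 mg/kg, the lowest number of the set. Among the measured compounds shown here, the only measured single change is a 3.3-fold higher number from compound 2 to compound 3 (0.52 log units; beyond the scatter), a modest rise when methyl replaces hydroxy.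

Compound 4 `COc1ccc(/C=C2/N=C(c3ccccc3)N(C(=O)c3ccc(C)cc3)NC2=O)cc1` differs from compound 3 by methoxy in place of methyl on an aromatic carbon. For the measured compounds named here, no measured step covers this exact swap. Compound 1 carries the same methoxy on that ring and gives a number level with compound 3, which hints that methoxy there does not pull the number down. The expectation for compound 4 in this assay is therefore a step of no change at the digits printed from compound 3 to compound 4 (within the scatter), that is, no change beyond the scatter. Compound 4 is expected to give about 100 mg/kg, most likely between 30 mg/kg and 300 mg/kg.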

Compound 4, dose for half-maximal effect: 100 mg/kg
Compound 4: the middle estimate sits on the measured number at the digits printed, within the range that was stated.
By their numbers in this assay, from the lowest: compound 2; then compounds 1, 3 and 4 (each within the scatter of the next).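

In this assay the swap from 4-methylphenyl to 4-methoxyphenyl gives no change at the digits printed from compound 3 to compound 4 (within the scatter) and so this position, para to a large group, takes either group without a shift beyond the scatter. Methyl in place of hydrogen on the oxygen of compound 2 gives a 3.3-fold higher number from compound 2 to compound 4 (0.52 log units; beyond the scatter) and this matches the rise seen when methyl replaces hydroxy, so among these compounds the lower number goes with the free hydroxy and not with the oxygen as such. Methyl in place of chloro on an aromatic carbon gives no change at the digits printed from compound 1 to compound 4 (within the scatter) and this adds a second place where a swap leaves the number unmoved.

On these data alone, whether an amine or a carboxylic acid at the benzylidene position would behave like the hydroxy of compound 2 stays open. Nothing in the data at hand explains why the numbers fall as they do.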